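This account rests on a few compounds, and the source may have more. Where it says the series, first, only, none or still open, it means among the compounds named here.

Of the compounds shown here, two of one series have been measured in an assay on isolated protein for inhibition of Amine oxidase [flavin-containing] B (Homo sapiens); a lower number here means a stronger inhibitor, a higher number a weaker inhibitor. Compound 1 `C#CCNC1CCc2c(SCc3cccc(C)c3)cccc21` reaches only the limit of the assay, giving > 100000 nM, a limit rather than a number (the limit of > 100000 nM in this assay, at which 1 of the 2 values shown sits). Compound 2 `C#CCNC1CCc2c(SCCc3ccc(Cl)cc3)cccc21` gives 10800 nM in this assay, the only actual number shown. Compound 3 `C#CCNC1CCc2c(SCCc3ccc(OC)cc3)cccc21` differs from compound 2 by one change: methoxy in place of chloro on an aromatic carbon. Compound 3 is expected to lose some potency, the estimated step of a 2.3-fold higher number from compound 2 to compound 3 (0.36 log units; beyond the scatter) running toward weaker inhibition and somewhat beyond the usual scatter. Compound 3 is thus estimated at 25000 nM, within a range of 8000 nM to 80000 nM.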

Compound 3, half-maximal inhibitory concentration: 62000 nM
Beside the measured number, compound 3's estimate is 2.5-fold (0.39 log units) below it; the measured number falls inside the stated range.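

In this assay, for the compounds shown here, the change from 4-chlorophenyl to 4-methoxyphenyl gives a 5.7-fold higher number from compound 2 to compound 3 (0.76 log units; beyond the scatter), the first comparison that can be read at a single place. It shows that the group para to a large group on this aromatic ring affects inhibition, with chloro the better of the two groups tested. Little room now remains before the assay's ceiling: the limit of > 100000 nM in this assay, at which 1 of the 3 values shown sits.

From the compounds shown here alone, what a bromo, a trifluoromethyl or a hydroxyl group would give at this place stays open. So does the effect of a longer chain on the sulfur.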